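Notes on the ring change from compound 3 to compound 4

The source may hold more compounds than are shown below. What is called first, only, known or untested is meant among the compounds shown, and "the series" means these compounds.

The series is followed in an ADME assay on a cell-free system (plasma, Rattus norvegicus) for metabolic stability, read by LC-MS, with a stated time of 1 h, at 37 degrees C, tested at 100 uM; a lower number here means that less of the compound is left, a higher number that more of the compound is left. Compound 1 `O=C1c2ccc(OCc3cccc(-c4ccc(Cl)cc4F)c3)cc2CN1C1CCCC1` has no reading here: "not determined" (no result reported). Compound 2 `O=C(O)c1cc(-c2cccc(COc3ccc4c(=O)n(CC5CC5)sc4c3)c2)ccc1Cl` gives 100% and compound 3 `O=C(O)c1cc(-c2cccc(COc3ccc4c(c3)CN(C3CCCC3)C4=O)c2)ccc1O` gives 98%. These two values lie within the scatter of each other, so compound 3 stands level with compound 2, with nearly all of the compound left.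

Compound 4 `Cc1ccc(C(=O)O)cc1-c1cccc(COc2ccc3c(c2)CN(C2CCCC2)C3=O)c1` differs from compound 3 in one place: 5-carboxy-2-methylphenyl in place of 3-carboxy-4-hydroxyphenyl on an aromatic carbon. No measured pair in the series isolates a change of this kind, so its effect is not shown directly. Among the measured compounds shown here, the only guide is that compound 2 at 100% and compound 3 at 98% differ in more than one place, yet their values stay within the scatter.

No step beyond the scatter is expected, and the estimated change a number 1 percentage points lower from compound 3 to compound 4 (within the scatter) has no clear direction. Compound 4 is expected at 97%, with an estimated range of 88% to 100%.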

Compound 4, percent of the compound remaining: 100%
The estimate for compound 4 lay 3 percentage points below the measured number; the range from low to high includes it.
By their numbers in this assay, from the lowest: compounds 3, 2 and 4 (each within the scatter of the next).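

In this assay, 5-carboxy-2-methylphenyl in place of 3-carboxy-4-hydroxyphenyl on an aromatic carbon gives a number 2 percentage points higher from compound 3 to compound 4 (within the scatter). Among the compounds shown here, this is the first pair that differs in one place, and it shows that this exchange at this position, with the carboxy group kept on both rings, does not move the reading beyond the scatter. Nothing at hand offers an explanation for this result.

The compounds shown leave open how a methyl ester or an amine in place of the carboxylic acid on this ring would read in this assay. Also open, from the compounds shown here alone, is whether a longer chain, such as propyl, in place of the methyl group of compound 4 would stay level with compound 4.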